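Thymidine-Derived Ureas: Cytotoxicity in Human Fibroblasts

The source may report more compounds than this note shows. Statements on the series, on what has been measured and on what is new or still open speak of the compounds shown alone.

The series rests on a shared core, seen in compound 1 `COc1ccc(NC(=O)NC[C@H]2O[C@H](n3cc(C)c(=O)[nH]c3=O)C[C@@H]2O)cc1`, which carries a urea linked to a methoxy-substituted phenyl ring. In an ADME assay on MRC5 cells (Homo sapiens) for cytotoxicity (on this read-out lower numbers stand for higher toxicity in this test and higher numbers for lower toxicity in this test), compound 1 gives a value reported only as a limit of the test, > 50000 nM. Compound 2 `Cc1cn([C@@H]2C[C@H](O)[C@@H](CNC(=O)Nc3ccc(C(C)(C)C)cc3)O2)c(=O)[nH]c1=O` differs from compound 1 by tert-butyl in place of methoxy on an aromatic carbon. In this assay compound 2 likewise reaches only a limit, > 50000 nM. Compound 3 `COc1ccc(COc2ccc(NC(=O)NC[C@H]3O[C@H](n4cc(C)c(=O)[nH]c4=O)C[C@@H]3O)cc2)cc1` differs from compound 1 by 4-methoxyphenyl in place of hydrogen on a saturated chain carbon bound to an oxygen on an aromatic ring. In this assay compound 3 also stands at a limit, > 50000 nM. Accordingly the step that the two limits leave unreadable from compound 1 to compound 2, the step that the two limits leave unreadable from compound 1 to compound 3 and the step that the two limits leave unreadable from compound 2 to compound 3 cannot be sized, since the limit of > 50000 nM in this assay, at which 3 of the 3 values shown sit, holds for every value in the set.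

Compound 4 `Cc1cn([C@@H]2C[C@H](O)[C@@H](CNC(=O)Nc3ccc(OCc4ccc(C(C)(C)C)cc4)cc3)O2)c(=O)[nH]c1=O` has not yet been measured. It differs from compound 3 by tert-butyl in place of methoxy on an aromatic carbon, the same change that separates compound 1 from compound 2, made on the same place of the ring but on a core that additionally carries the difference told above for compound 3. Since compound 1 and compound 2 both sit at the limit, the measured instance of this change gives no readable size to compare with. For compound 4 the step that the limit leaves unreadable from compound 3 to compound 4 is expected to be small, and compound 4 is estimated to sit at 60000 nM, most probably again as a limit rather than a number, within a band from 30000 nM to 150000 nM.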

Compound 4, half-maximal cytotoxic concentration: > 50000 nM
Compound 4: a limit, no number; the forecaster's own chance of this, stated with the estimate: 80%; the middle value does not contradict the limit.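

In this assay compound 4 gives > 50000 nM, again a limit of the test and not a number. Among these compounds, no step from compound 1, compound 2 or compound 3 to compound 4 can be read, because all four compounds rest on the same limit: the limit of > 50000 nM in this assay, at which 4 of the 4 values shown sit. The compounds shown leave open what size, if any, each of these changes on the shared core has on this read-out.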